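The source may report more compounds than this note shows. Statements on the series, on what has been measured and on what is new or still open speak of the compounds shown alone.

Working notes on the series, read in a functional assay on A2780 cells (Homo sapiens) for antiproliferative activity, read by CellTiter-Glo, with a stated time of 4 days; a lower number here means a stronger inhibitor, a higher number a weaker inhibitor. Compound 1 (`CCC(=O)N[C@@H](C)c1ccc(NC(=O)[C@H]2C[C@@H]2c2cccnc2)cc1`) gives 5 nM and compound 2 (`C[C@H](NC(=O)CC(F)(F)F)c1ccc(NC(=O)[C@H]2C[C@@H]2c2cccnc2)cc1`) gives 5 nM, with no change at the digits printed from compound 1 to compound 2 (within the scatter). Compound 3 (`C[C@H](NC(=O)[C@@H]1CCCN1C)c1ccc(NC(=O)[C@H]2C[C@@H]2c2cccnc2)cc1`) gives 1 nM, the lowest of the three numbers.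

Next is compound 4 (`C[C@H](NC(=O)c1ccc(C#N)cc1)c1ccc(NC(=O)[C@H]2C[C@@H]2c2cccnc2)cc1`), with this change: 4-cyanophenyl in place of 1-methylpyrrolidin-2-yl on a carbonyl carbon. That places 4-cyanophenyl in place of 1-methylpyrrolidin-2-yl on a carbonyl carbon.

For the measured compounds named here, no measured compound carries 4-cyanophenyl. The closest evidence is the pair of modest steps that brought in the departing group: a 5.0-fold lower number from compound 1 to compound 3 (0.70 log units; beyond the scatter) and a 5.0-fold lower number from compound 2 to compound 3 (0.70 log units; beyond the scatter). With that group gone, part or all of this gain is expected to be lost.

A modest rise is therefore expected in this assay, estimated as a 4.0-fold higher number from compound 3 to compound 4 (0.60 log units; beyond the scatter). For compound 4 the expected value is 4 nM, with an estimated range of 1 nM to 15 nM.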

Compound 4, half-maximal inhibitory concentration: 4 nM
The estimate for compound 4 equals the measured number at the digits printed; the measured number falls inside the stated range.
By their numbers in this assay, from the lowest: compound 3; then compounds 4, 1 and 2 (each within the scatter of the next).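

In this assay, 4-cyanophenyl on this carbonyl carbon does not keep the lower number seen with 1-methylpyrrolidin-2-yl (a 4.0-fold higher number from compound 3 to compound 4 (0.60 log units; beyond the scatter)). Its steps from the two open-chain groups stay within the scatter (a 1.3-fold lower number from compound 1 to compound 4 (0.10 log units; within the scatter); a 1.3-fold lower number from compound 2 to compound 4 (0.10 log units; within the scatter)), so an aromatic ring of carbon only cannot be told apart from ethyl or 2,2,2-trifluoroethyl here, and among these four compounds only 1-methylpyrrolidin-2-yl stands apart. No measurement at hand accounts for this result.

As far as these compounds go, whether the lower number follows the ring, its nitrogen or its stereocentre remains open. The unmethylated pyrrolidin-2-yl, the opposite stereoisomer and an open-chain dimethylaminomethyl group would separate these.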